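Amide series against the bile acid receptor: restoring the aryl terminus

The compounds below may be only part of what the source reports. "The series", "measured", "known", "first", "only" and "open" are said of these compounds alone.

Measured compounds:
compound 1, `COC(=O)/C=C/c1cccc(N(Cc2ccc(/C=C/c3c(Cl)cccc3Cl)cc2)C(=O)C(C)C)c1` — 195 nM
compound 2, `COC(=O)/C=C/c1cccc(N(Cc2ccc(-c3ccc(OC)cc3)cc2)C(=O)C2CCCCC2)c1` — 89 nM
compound 3, `CCOC/C=C/c1ccc(CN(C(=O)C2CCCCC2)c2cccc(/C=C/C(=O)OC)c2)cc1` — 198000 nM

In an assay on isolated protein with Bile acid receptor (Homo sapiens) as the target (a higher number here means that more compound is needed for the effect, a lower number that less compound is needed), compound 3 gives the highest number of the three, with compound 1 nearest and compound 2 furthest. For the measured compounds named here, the single step available, a 2200-fold higher number from compound 2 to compound 3 (3.35 log units; beyond the scatter), is the only guide here and is large. Compound 4, `COC(=O)/C=C/c1cccc(N(Cc2ccc(/C=C/c3c(Cl)cccc3Cl)cc2)C(=O)C2CCCCC2)c1`, differs from compound 3 by 2,6-dichlorophenyl in place of ethoxymethyl on a double-bonded chain carbon bound to a double-bonded chain carbon, so the chain terminus again carries a six-membered aromatic ring, as in compound 1 and compound 2. Compound 4 shares its ethenyl-linked dichlorophenyl terminus with compound 1, which gives 195 nM with an isobutyryl amide, while compound 2 shares the cyclohexanecarbonyl amide and gives 89 nM. Because a 2200-fold higher number from compound 2 to compound 3 (3.35 log units; beyond the scatter) shows how much is lost when the ring is removed, a reversal of similar size is expected here, and compound 4 is estimated at a 1700-fold lower number from compound 3 to compound 4 (3.22 log units; beyond the scatter). Compound 4 is therefore expected at 120 nM, within 40 nM to 400 nM.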

Compound 4, half-maximal effective concentration: 150 nM
Beside the measured number, compound 4's estimate is 1.3-fold (0.10 log units) below it, within the range that was stated.
By their numbers in this assay, from the lowest: compounds 2, 4 and 1 (each within the scatter of the next, the first and the last beyond it); then compound 3.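

With 2,6-dichlorophenyl in place of ethoxymethyl, this assay gives a 1300-fold lower number from compound 3 to compound 4 (3.12 log units; beyond the scatter) while the double-bonded chain carbon stays in place, so the low number at this position goes with the aromatic terminus and not with the double-bonded chain alone. Two different aromatic termini cannot be separated here, since a 1.7-fold higher number from compound 2 to compound 4 (0.23 log units; within the scatter) stays within the scatter for 2-(2,6-dichlorophenyl)ethenyl against 4-methoxyphenyl. The amide side is likewise not separated, with a 1.3-fold lower number from compound 1 to compound 4 (0.11 log units; within the scatter) for cyclohexyl in place of isopropyl on a carbonyl carbon, which is also within the scatter.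

Still open, as far as these compounds go, is whether a saturated ring such as cyclohexyl, or a pyridine ring, at the chain terminus would hold the low number, or whether only a six-membered aromatic ring of carbon does so. The material at hand offers no independent data that explain the size of the gap between the ethoxymethyl and aromatic termini.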